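The compounds below may be only part of what the source reports. "The series", "measured", "known", "first", "only" and "open" are said of these compounds alone.

Of the compounds shown here, three of one shared core have been measured in an assay on HEK293 cells for inhibition of neurogenic locus notch homolog protein 1 (Homo sapiens), read by a luciferase reporter and resazurin assay, with a stated time of 16 h; a higher number here means a weaker inhibitor, a lower number a stronger inhibitor. Compound 1 `CC1=C(C(=O)OCc2cnccn2)C(c2cccc(Br)c2)C2=C(CC(C)(C)CC2=O)N1` gives 860 nM. Compound 2 `CC1=C(C(=O)OCC2CCN(C(=O)OC(C)(C)C)CC2)C(c2cccc(C#N)c2)C2=C(CC(C)(C)CC2=O)N1` gives 220 nM, the lowest of the three numbers. Compound 3 `CC1=C(C(=O)OCC2CCN(C(=O)OC(C)(C)C)CC2)C(c2cccc(-c3ccc4[nH]ccc4c3)c2)C2=C(CC(C)(C)CC2=O)N1` gives 770 nM. Compound 2 stands nearest to compound 3 and furthest from compound 1, in both cases beyond the scatter.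

Compound 4 `CC1=C(C(=O)OCC2CCN(C(=O)OC(C)(C)C)CC2)C(c2ccc(-c3ccccc3)cc2)C2=C(CC(C)(C)CC2=O)N1` has not yet been measured. It differs from compound 2 in one place: 4-phenylphenyl in place of 3-cyanophenyl on a saturated ring carbon. Within the data shown here, the one measured step that bears on this change is a 3.5-fold higher number from compound 2 to compound 3 (0.54 log units; beyond the scatter), where a larger aromatic group likewise replaced the cyano group on the aromatic ring of compound 2. Compound 1, with bromine on that ring and a different ester, also sits well above compound 2. From these numbers a step toward a higher value is expected for compound 4, of about a 3.2-fold higher number from compound 2 to compound 4 (0.50 log units; beyond the scatter). Compound 4 is therefore estimated at 700 nM, with a range from 250 nM to 2000 nM.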

Compound 4, half-maximal inhibitory concentration: > 10000 nM
Compound 4 was reported as a limit; the forecaster's own chance of this, stated with the estimate: 5%; middle value at least 14-fold (1.15 log units) away from the limit.
By their numbers in this assay, from the lowest: compound 2; then compounds 3 and 1 (each within the scatter of the next). At a limit, above all of these: compound 4.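

In this assay compound 4 is the only compound shown that is reported as a limit and not as a number: the limit of > 10000 nM in this assay, at which 1 of the 4 values shown sits. Placing 4-phenylphenyl in place of 3-cyanophenyl on this saturated ring carbon gives an at least 45-fold higher number from compound 2 to compound 4 (1.65 log units; beyond the scatter), so this position does not accept every change of aryl group equally. Among these compounds, the earlier 3.5-fold higher number from compound 2 to compound 3 (0.54 log units; beyond the scatter) was a modest step, and it showed only part of this: compounds 3 and 4 both carry an added aromatic ring, yet only the step to compound 4 is large.

The compounds shown do not tell whether the loss goes with the second phenyl ring itself or with the place where the ring is substituted. A plain phenyl group, or a ring bearing an amine or a carboxylic acid, lies outside what is shown here.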